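Swapping dimethylamino for amino at the limit of detection

The compounds below may be only part of what the source reports. "The series", "measured", "known", "first", "only" and "open" are said of these compounds alone.

In a functional assay on HCT-116 cells (Homo sapiens) for antiproliferative activity, read by MTT assay, with a stated time of 48 h (on this read-out lower numbers stand for stronger inhibition and higher numbers for weaker inhibition), compound 1 `CCCCCC(CCO)n1cnc2c(N)ncnc21` gives > 50000 nM as its reading, which is a limit and not a number. Compound 2 `CCCCCCCC(CCO)n1cnc2c(N(C)C)ncnc21` gives > 50000 nM as its reading, again a limit. So the limit of > 50000 nM in this assay, at which 2 of the 2 values shown sit, is where compound 2 stands. Compound 3 `CCCCCCCC(CCO)n1cnc2c(N)ncnc21` differs from compound 2 in one place: amino in place of dimethylamino on an aromatic carbon with amino in place of dimethylamino on an aromatic carbon. Compound 1 also carries amino and gives > 50000 nM as a limit. In this assay the expected step of a number no higher from compound 2 to compound 3 (the limit leaves the size open) is none beyond the scatter. Compound 3 is expected near 50000 nM within a range of 20000 nM to 120000 nM on this estimate.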

Compound 3, half-maximal inhibitory concentration: > 50000 nM
Compound 3: only a limit was reported; the forecaster's own chance of this, stated with the estimate: 60%; the middle value lies on the limit itself.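

Compound 3 also gives only a limit, so neither its step from compound 1 nor its step from compound 2 can be read: the limit of > 50000 nM in this assay, at which 3 of the 3 values shown sit. From the compounds shown here alone, what amino in place of dimethylamino, or ethyl in place of hydrogen, does to the reading stays open.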